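The source may hold more compounds than are shown below. What is called first, only, known or untested is meant among the compounds shown, and "the series" means these compounds.

Compound 1 `O=C(Nc1cc(-c2ccccc2)nn1-c1ccccc1)c1ccc(C(F)(F)F)cc1` is the amide of the shared core; in an assay on HEK293 cells for displacement of a labelled ligand from metabotropic glutamate receptor 5 (Rattus norvegicus) (on this read-out higher numbers stand for weaker inhibition and lower numbers for stronger inhibition), compound 1 gives 990 nM. Of the two numbers shown for this series, that of compound 1 is the higher one. Compound 3 `O=C(Nc1cc(-c2ccccc2)nn1-c1ccccc1Br)c1cccc([N+](=O)[O-])c1` in this assay gives 230 nM, a lower number than that of compound 1, and the gap between the two lies beyond the usual scatter. Compound 2 `O=C(Nc1cc(-c2ccccc2)nn1-c1cccc(Br)c1)c1ccccc1` in this assay returns only a limit, > 10000 nM; this is the limit of > 10000 nM in this assay, at which 1 of the 3 values shown sits. The unmeasured compound 4 `Cc1ccc(C(=O)Nc2cc(-c3ccccc3)nn2-c2ccccc2)cn1` differs from compound 1 in one place: 6-methylpyridin-3-yl in place of 4-(trifluoromethyl)phenyl on a carbonyl carbon. Going by the values given here, no measured pair isolates this change, and neither compound 2 nor compound 3 varies this part of the amide, so no direction can be read from the measured compounds. The expected step is a 1.5-fold higher number from compound 1 to compound 4 (0.18 log units; within the scatter), none beyond the usual scatter. For compound 4 in this assay a value of 1500 nM is estimated, with a range from 400 nM to 6000 nM.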

Compound 4, inhibition constant: 3480 nM
Compound 4: the middle estimate sits 2.3-fold (0.37 log units) below what was measured, within the range that was stated.
By their numbers in this assay, from the lowest: compound 3; then compound 1; then compound 4. At a limit, above all of these: compound 2.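

In this assay, 6-methylpyridin-3-yl in place of 4-(trifluoromethyl)phenyl on a carbonyl carbon gives a 3.5-fold higher number from compound 1 to compound 4 (0.55 log units; beyond the scatter). Going by these compounds alone, this is the first pair to isolate this position, and it shows that the group on the carbonyl carbon can shift the number beyond the usual scatter, although the step is modest. Nothing shown gives a cause for this step.

As far as these compounds go, it remains open which difference carries the step: the ring nitrogen, the methyl or the loss of the trifluoromethyl, a question that unsubstituted pyridin-3-yl or 4-methylphenyl on the carbonyl carbon would help to separate. Also open, from the compounds shown here alone, is whether the same step would hold with the bromine-bearing aryl groups of compound 2 and compound 3.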